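The source may report more compounds than this note shows. Statements on the series, on what has been measured and on what is new or still open speak of the compounds shown alone.

In an ADME assay on the whole organism (Mus musculus, strain CD1) for pharmacokinetics, at a dose of 2 mg/kg by the intravenous route (a higher number here means faster removal of the compound, a lower number slower removal), compound 1 (`COc1cc(N2C(=O)C3(CCC3)N(c3ccc(OC4CCN(C)CC4)nc3)C2=S)cnc1C#N`) gives 8.8 mL/min/kg and stands highest of the two measured compounds, with compound 2 (`CN1CCC(Oc2ccc(N3C(=S)N(c4cnc(C#N)c(C(F)(F)F)c4)C(=O)C34CCC4)cc2)CC1`) at 4.12 mL/min/kg and the gap beyond the scatter. Compound 3 (`CN1CCC(Oc2ccc(N3C(=S)N(c4cnc(C#N)c(C(F)(F)F)c4)C(=O)C34CCC4)cn2)CC1`) differs from compound 1 by trifluoromethyl in place of methoxy on an aromatic carbon on an aromatic carbon ortho to a cyano group. Going by the values given here, no measured step isolates this change. Compound 2 also carries trifluoromethyl, and its 4.12 mL/min/kg points to a modest expected fall in this assay near the scatter. The estimated step is a 1.5-fold lower number from compound 1 to compound 3 (0.17 log units; within the scatter) in size. For compound 3 the estimate is 6 mL/min/kg with 3 mL/min/kg to 11 mL/min/kg as the expected range.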

Compound 3, clearance: 8.14 mL/min/kg
Estimate against measurement, compound 3: 1.4-fold (0.13 log units) below; the measured number falls inside the stated range.
By their numbers in this assay, from the lowest: compounds 2, 3 and 1 (each within the scatter of the next, the first and the last beyond it).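

Swapping methoxy for trifluoromethyl on the aromatic carbon ortho to a cyano group gives a 1.1-fold lower number from compound 1 to compound 3 (0.03 log units; within the scatter) in this assay and is the first direct reading of this change in the series. On this read-out, the position tolerates two quite different substituents, with the step staying within the scatter. This single pair does not show whether that holds for other substituents at this position, such as a fluorine atom, an amine or a longer alkoxy chain. No supporting measurement bears on why methoxy and trifluoromethyl read alike here.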